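The source may hold more compounds than are shown below. What is called first, only, known or untested is meant among the compounds shown, and "the series" means these compounds.

Measured compounds:
Compound 1, `O=C(O)C[C@@H]1CCCN1c1ccc(Oc2ccccc2)cc1`, gives 560 nM.
Compound 2, `O=C(O)C[C@@H]1CCCN1c1ccc(Oc2ccc(Cl)cc2Cl)cc1`, gives 360 nM.

Within the data shown here, in a functional assay on cells for agonist activity at Free fatty acid receptor 1 (Homo sapiens), read by FLIPR and calcium flux, with a stated time of 100 s (a higher number here means that more compound is needed for the effect, a lower number that less compound is needed), compound 1 has the highest of the two numbers, and its only neighbour is compound 2, reached by a 1.6-fold lower number from compound 1 to compound 2 (0.19 log units; within the scatter), so on what has been measured it is not separated from compound 2. Compound 3, `CCOc1ccccc1Oc1ccc(N2CCC[C@H]2CC(=O)O)cc1`, differs from compound 1 by ethoxy in place of hydrogen on an aromatic carbon, on the outer ring that hangs from the oxygen, ortho to a large group. Among the measured compounds shown here, the one step that bears on it is the exchange of that same outer ring in a 1.6-fold lower number from compound 1 to compound 2 (0.19 log units; within the scatter), which stayed within the scatter. That is thin evidence, but it suggests that decorating the outer ring moves the number little. For compound 3 the expected step is a 1.2-fold lower number from compound 1 to compound 3 (0.09 log units; within the scatter), that is, no change beyond the scatter. The estimate for compound 3 is therefore 450 nM, with a range from 150 nM to 1500 nM.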

Compound 3, half-maximal effective concentration: 1700 nM
Estimate against measurement, compound 3: 3.8-fold (0.58 log units) below; the measured number lies above the stated range.
By their numbers in this assay, from the lowest: compounds 2 and 1 (each within the scatter of the next); then compound 3.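

Ethoxy in place of hydrogen, on an aromatic carbon ortho to a large group, brings a 3.0-fold higher number from compound 1 to compound 3 (0.48 log units; beyond the scatter) in this assay and so shows that the outer ring does not accept every added group without a cost. Among these compounds, the only earlier change to that ring, a 1.6-fold lower number from compound 1 to compound 2 (0.19 log units; within the scatter) in this assay, gave no hint of this, so the outer ring can no longer be treated as a place where changes leave the number alone. Nothing available explains the rise at this position.

On these data alone, with only ethoxy tested at this place, it remains open whether methoxy, a fluorine atom or a longer chain such as propoxy would give a similar rise. As far as these compounds go, it is equally open whether ethoxy on a different carbon of the same ring would raise the number at all.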